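Removing the bromine from the benzoyl arm

The compounds below may be only part of what the source reports. "The series", "measured", "known", "first", "only" and "open" are said of these compounds alone.

Compound 1 `COc1cc(-c2nnc3n2NC(c2ccco2)C(C(=O)c2ccc(Br)cc2)S3)cc(OC)c1OC` is the bromo-bearing member of the pair measured so far. In a functional assay on MCF7 cells (Homo sapiens) for cytotoxicity, read by MTT assay, with a stated time of 48 h (a lower number here means a stronger inhibitor, a higher number a weaker inhibitor), compound 1 gives only a limit of the assay, > 100000 nM. That limit is where one of the two values sits (the limit of > 100000 nM in this assay, at which 1 of the 2 values shown sits). Compound 2 `COc1cc(-c2nnc3n2NC(c2cccs2)C(C(=O)c2ccc(F)cc2)S3)cc(OC)c1OC` gives 43700 nM in this assay. Compound 3 `COc1cc(-c2nnc3n2NC(c2ccco2)C(C(=O)c2ccccc2)S3)cc(OC)c1OC` is not yet measured; it differs from compound 1 by hydrogen in place of bromo on an aromatic carbon, 4-bromophenyl to phenyl. Among the compounds with values here, no measured step covers this change, so the expected step from compound 1 to compound 3 is modest, an at least 1.2-fold lower number from compound 1 to compound 3 (0.09 log units; that floor lies within the scatter), probably not beyond the scatter. Compound 3 is accordingly estimated at 80000 nM, between 20000 nM and 300000 nM.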

Compound 3, half-maximal inhibitory concentration: 39800 nM
Compound 3: middle estimate off by 2.0-fold (0.30 log units), on the high side; measured number inside the range.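

Hydrogen in place of bromo on the aromatic carbon gives the first readable step at this position in this assay, an at least 2.5-fold lower number from compound 1 to compound 3 (0.40 log units; beyond the scatter). The bromo group is therefore not required for a measurable value in this series, as the benzoyl form compound 3 shows. The size of the step is only a floor, because the value of compound 1 is a limit of the assay: the limit of > 100000 nM in this assay, at which 1 of the 3 values shown sits.

On these data alone, whether an amine or a carboxylic acid on the same aromatic carbon would lower the number further stays open.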